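Fluoro to trifluoromethoxy: a step awaiting measurement

The compounds below may be only part of what the source reports. "The series", "measured", "known", "first", "only" and "open" are said of these compounds alone.

Measured so far:
compound 1, `CC(C)N(C(=O)CN1C=CN(c2ccccc2)C(=O)C(Cc2n[nH]c3ccccc23)C1=O)c1ccc(F)cc1`: 282 nM
compound 2, `CC(C)N(C(=O)CN1C=CN(c2ccccc2)C(=O)C(Cc2n[nH]c3ccccc23)C1=O)c1ccc(O)cc1`: 1000 nM; 1000 nM; 31600 nM; > 30000 nM (4 entries)

For the measured compounds named here, in a functional assay on CHO cells for agonist activity at Melanocortin receptor 4 (Homo sapiens), read by a luciferase reporter, with a stated time of 4 h (a lower number here means that less compound is needed, a higher number that more compound is needed for the effect), compound 1 gives 282 nM, the only single number in this set. Compound 2 has several entries in this assay, namely 1000 nM; 1000 nM; 31600 nM; > 30000 nM (4 entries) (the several entries of compound 2 in this assay, 1000 nM; 1000 nM; 31600 nM; > 30000 nM (4 entries)). Going by the values given here, no step between measured compounds that differ in one place exists, so compound 2 stands only as the other measured member, and its values are noted without comparison.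

The next compound, compound 3 `CC(C)N(C(=O)CN1C=CN(c2ccccc2)C(=O)C(Cc2n[nH]c3ccccc23)C1=O)c1ccc(OC(F)(F)F)cc1`, differs from compound 1 by trifluoromethoxy in place of fluoro on an aromatic carbon. Among the compounds with values here, with no measured step to lean on, the expected change is modest: the estimated step is a 1.4-fold higher number from compound 1 to compound 3 (0.15 log units; within the scatter), which is expected to stay within the usual scatter. For compound 3 the estimate in this assay is 400 nM, with the range 100 nM to 2500 nM.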

Compound 3, half-maximal effective concentration: 151 nM
Beside the measured number, compound 3's estimate is 2.6-fold (0.42 log units) above it; low and high end bracket the measured number.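

In this assay, trifluoromethoxy in place of fluoro on an aromatic carbon, para to a large group, gives a 1.9-fold lower number from compound 1 to compound 3 (0.27 log units; within the scatter). For the compounds shown here, this is the first readable step, and it shows that 5 heavy atoms and a hydrogen-bond acceptor can enter at this position, where a single fluorine stood, with no change beyond the scatter. Nothing shown here accounts for this outcome.

The steps involving compound 2 cannot be read, so the place of hydroxy at this position relative to fluoro and trifluoromethoxy stays unsettled. On these data alone, whether a charged group such as an amine or a carboxylic acid, or a longer chain, would stay within the scatter of compound 1 remains open.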